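Acetylation steps across a diterpenoid lactone series

The source may hold more compounds than are shown below. What is called first, only, known or untested is meant among the compounds shown, and "the series" means these compounds.

Compound 1 `C=C1CC[C@@H]2[C@](C)(COC(C)=O)[C@H](OC(C)=O)CC[C@@]2(C)[C@@H]1C/C=C1/C(=O)OC[C@H]1OC(C)=O`, compound 2 `C=C1CC[C@@H]2[C@](C)(CO)[C@H](OC(C)=O)CC[C@@]2(C)[C@@H]1C/C=C1/C(=O)OC[C@H]1OC(C)=O` and compound 3 `C=C1CC[C@@H]2[C@](C)(CO[Si](C)(C)C(C)(C)C)[C@H](O)CC[C@@]2(C)[C@@H]1C/C=C1/C(=O)OC[C@H]1O` have been measured in a functional assay on P388 cells (Mus musculus) for cytotoxicity, read by sulforhodamine B assay; on this read-out lower numbers stand for an effect already at smaller amounts and higher numbers for an effect only at larger amounts of compound. Compound 2 gives 0.69 uM, and compound 1 gives 1.4 uM. The step between them, a 2.0-fold higher number from compound 2 to compound 1 (0.31 log units; beyond the scatter), is acetyl in place of hydrogen on an oxygen on a saturated carbon. Compound 3 gives 8.39 uM, the highest number of the three; the difference between the core of compound 3 and the core of compound 2 is not broken down here.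

Compound 4 `C=C1CC[C@@H]2[C@](C)(CO[Si](C)(C)C(C)(C)C)[C@H](OC(C)=O)CC[C@@]2(C)[C@@H]1C/C=C1/C(=O)OC[C@H]1O` is not yet measured in this assay. Compound 4 differs from compound 3 by acetyl in place of hydrogen on an oxygen on a saturated carbon. This is the same kind of change as that from compound 2 to compound 1, not the same: in the earlier pair the oxygen sits on a saturated carbon whose other neighbour is a saturated chain carbon, here on a saturated carbon whose other neighbour is a saturated ring carbon. Going by the values given here, with only one earlier step of this kind, the expected step from compound 3 to compound 4 is a 1.2-fold higher number from compound 3 to compound 4 (0.08 log units; within the scatter), resting on the modest size of a 2.0-fold higher number from compound 2 to compound 1 (0.31 log units; beyond the scatter) and on the position of compound 3 at 8.39 uM. Compound 4 is therefore estimated at 10 uM, with a likely range from 3 uM to 30 uM.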

Compound 4, concentration for half-maximal effect: 1.71 uM
Compound 4: the middle estimate sits 5.8-fold (0.77 log units) above what was measured; the measured number lies below the stated range.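

In this assay, acetyl in place of hydrogen on an oxygen on a saturated carbon gives a 4.9-fold lower number from compound 3 to compound 4 (0.69 log units; beyond the scatter), so the change lowers the number here, whereas it raised the number on the earlier pair. Set side by side, the two steps differ in direction and lie further apart than scatter would account for: the same change on two cores in this assay, a 2.0-fold higher number (0.31 log units; beyond the scatter) from compound 2 to compound 1 and a 4.9-fold lower number (0.69 log units; beyond the scatter) from compound 3 to compound 4, 10-fold (1.00 log units) apart, beyond the scatter of two such steps. This shows that neither the size nor the direction of the acetyl step can be carried from one core to the other in this series, but with a single pair on each core it does not show whether the difference follows the place of the oxygen, on a saturated carbon whose other neighbour is a saturated ring carbon in the new pair, or some other difference between the cores.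

Open, from the compounds shown here alone, is whether a longer acyl chain such as butanoyl on this oxygen would follow the acetyl step. Also open, going by these compounds, is how that step would read with a carboxylic acid in place of the tert-butyldimethylsilyl group.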